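This account rests on a few compounds, and the source may have more. Where it says the series, first, only, none or still open, it means among the compounds named here.

Compound 1 (`c1ccc(Sc2c(-c3cccc4ccccc34)nc3ccccn23)cc1`) 9900 nM
Compound 2 (`C(=C/c1nc2ccccn2c1Sc1ccccc1)\c1ccccc1`) 8800 nM
Compound 3 (`Clc1ccc2nc(-c3ccccc3)c(Sc3ccccc3)n2c1`) 15700 nM

These three compounds were tested in a functional assay on HepG2 cells (Homo sapiens) for inhibition, read by MTT assay, with a stated time of 48 h; a higher number here means a weaker inhibitor, a lower number a stronger inhibitor. Compound 2 gives 8800 nM and lies within the scatter of both compound 1 and compound 3, so the three cannot be ranked. Compound 4 (`Clc1ccc(-c2nc3ccccn3c2Sc2ccccc2)cc1`) carries 4-chlorophenyl in place of 2-phenylethenyl on an aromatic carbon and keeps the phenylsulfanyl group of compound 2. Among the measured compounds shown here, no measured step exists to draw on. Still, compound 1 at 9900 nM and compound 3 at 15700 nM carry other groups and remain within the scatter of compound 2, so no step beyond the scatter is expected in this assay and no firm direction can be given. The estimated change is small (a 1.3-fold higher number from compound 2 to compound 4 (0.10 log units; within the scatter)). Compound 4 is estimated at 11000 nM (expected range 5000 nM to 24000 nM).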

Compound 4, half-maximal inhibitory concentration: 13900 nM
Beside the measured number, compound 4's estimate is 1.3-fold (0.10 log units) below it; measured number inside the range.
By their numbers in this assay, from the lowest: compounds 2, 1, 4 and 3 (each within the scatter of the next).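

Among the compounds shown here, this gives the first direct step at this position in this assay, where 4-chlorophenyl takes the place of 2-phenylethenyl: a 1.6-fold higher number from compound 2 to compound 4 (0.20 log units; within the scatter), which lies within the scatter. The exchange of a chain with a double bond outside aromatic rings for a directly attached chlorinated ring therefore does not separate the two compounds in this assay. No measured evidence bears on the reason for this result. As far as these compounds go, whether an amine or a carboxylic acid on this aromatic carbon would give a step beyond the scatter remains open. From the compounds shown here alone, whether replacing the phenylsulfanyl group would do so also remains open.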